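This account rests on a few compounds, and the source may have more. Where it says the series, first, only, none or still open, it means among the compounds named here.

Values measured in a functional assay on HCT-116 cells (Homo sapiens) for inhibition, read by MTT assay, with a stated time of 48 h; a higher number here means a weaker inhibitor, a lower number a stronger inhibitor:

Compound 1 `COc1cc(NCc2ccccc2)cc(OC)c1OC`: > 80000 nM
Compound 2 `COC(=O)c1cc(CNc2cc(OC)c(OC)c(OC)c2)ccc1OC`: 38100 nM
Compound 3 `COc1ccc(CNc2cc(OC)c(OC)c(OC)c2)cc1C`: 60900 nM

The entry for compound 1, > 80000 nM, is a limit of the assay and not a number. Compound 3, at 60900 nM, lies within the scatter of compound 2, at 38100 nM, so these two cannot be told apart in this assay.

The next compound is compound 4 `COc1ccc(CNc2cc(OC)c(OC)c(OC)c2)cc1`, which has hydrogen in place of methyl on an aromatic carbon. Going by the values given here, one measured step bears on this change, since it also swaps the group on that carbon. That step, a 1.6-fold higher number from compound 2 to compound 3 (0.20 log units; within the scatter), stays within the scatter. A swap of methoxycarbonyl for methyl thus left the reading in this assay essentially unmoved, and no step beyond the scatter is expected here either. The expected step is a 1.1-fold lower number from compound 3 to compound 4 (0.04 log units; within the scatter). A reading at the limit remains possible. For compound 4 the estimated value is 55000 nM, with an expected range of 25000 nM to 110000 nM.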

Compound 4, half-maximal inhibitory concentration: 18400 nM
The estimate for compound 4 lay 3.0-fold (0.48 log units) above the measured number; the measured number lies below the stated range.
By their numbers in this assay, from the lowest: compound 4; then compounds 2 and 3 (each within the scatter of the next). At a limit, above all of these: compound 1.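

In this assay, removing the methyl from the carbon ortho to a methoxy group gives a real gain, with hydrogen there producing a 3.3-fold lower number from compound 3 to compound 4 (0.52 log units; beyond the scatter) and, against methoxycarbonyl at the same carbon, a 2.1-fold lower number from compound 2 to compound 4 (0.32 log units; beyond the scatter), whereas the swap between those two larger groups gave only a 1.6-fold higher number from compound 2 to compound 3 (0.20 log units; within the scatter) and stayed within the scatter. This carbon therefore does respond to substitution, and both groups tried there read weaker than hydrogen, while methoxy in place of hydrogen on an aromatic carbon gives an at least 4.3-fold lower number from compound 1 to compound 4 (0.63 log units; beyond the scatter). The entry for compound 1 is a limit of the assay and not a number: the limit of > 80000 nM in this assay, at which 1 of the 4 values shown sits.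

From the compounds shown here alone, whether any group at this carbon could go below hydrogen remains open, for instance fluorine, a hydroxyl or an amine. How far these gains carry beyond this short series, with every reading still weak, is also unsettled.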